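Lengthening the Amino Chain of Compound 3

The source may report more compounds than this note shows. Statements on the series, on what has been measured and on what is new or still open speak of the compounds shown alone.

Measured in a functional assay on T-24 cells (Homo sapiens) for cytotoxicity, read by neutral red uptake, with a stated time of 72 h; a lower number here means a stronger inhibitor, a higher number a weaker inhibitor:
- compound 1 `c1ccc(CCCNc2nc(NCCCc3ccccc3)c3ccccc3n2)cc1`: 3450 nM
- compound 2 `c1ccc(CCCCNc2nc(NCCCCc3ccccc3)c3ccccc3n2)cc1`: 11900 nM
- compound 3 `CCNc1nc(SCC)nc2ncccc12`: 20100 nM

Compound 3 stands with the highest number of the three in this assay; compound 2 sits close to it, within the scatter, while compound 1 lies well below it, beyond the scatter. Compound 4 `CCCCNc1nc(SCC)nc2ncccc12` differs from compound 3 by ethyl in place of hydrogen on a saturated chain carbon, two bonds along the chain from a nitrogen on an aromatic ring. For the measured compounds named here, no measured pair shows this change, so its size is unknown; compounds 1 and 2 differ elsewhere and only show that compound 1 gives the lower number of the two. The step from compound 3 to compound 4 is expected to be modest, a 1.3-fold lower number from compound 3 to compound 4 (0.13 log units; within the scatter), with no clear direction beyond the scatter. Compound 4 is estimated at 15000 nM, within a range from 5000 nM to 50000 nM.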

Compound 4, half-maximal inhibitory concentration: 20900 nM
For compound 4 the middle estimate is 1.4-fold (0.14 log units) below the measured one, within the range that was stated.
By their numbers in this assay, from the lowest: compound 1; then compounds 2, 3 and 4 (each within the scatter of the next).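

In this assay, ethyl in place of hydrogen on this saturated chain carbon, which turns ethylamino into butylamino, gives a 1.0-fold higher number from compound 3 to compound 4 (0.02 log units; within the scatter). For the compounds shown here, this is the first direct reading of the change at this position, and it shows that ethylamino and butylamino cannot be told apart in this assay. No supporting data bear on this result.

Going by these compounds, whether a longer chain, such as hexylamino, would move the number remains open. So does the effect of an amine or a carboxylic acid at the end of the chain.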